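The compounds below may be only part of what the source reports. "The series", "measured", "known", "first", "only" and "open" are said of these compounds alone.

Working notes on the series. The shared core carries a cinnamoyl-type side chain on each compound; compound 1 `CCCC1=C(OCC(C)C)C(CCC)(CCC)C(=O)/C(=C(O)\C=C\c2ccccc2)C1=O` has an isobutoxy group and three propyl chains. In a functional assay on HepG2 cells (Homo sapiens) for antiproliferative activity, read by sulforhodamine B assay, with a stated time of 3 days (a higher number here means that more compound is needed for the effect, a lower number that less compound is needed), compound 1 gives 13.4 uM. Among the compounds with values here, compound 2 `COC1=C(CC=C(C)C)C(=O)/C(=C(O)/C=C/c2ccccc2)C(=O)C1(CC=C(C)C)CC=C(C)C`, with a methoxy group and three prenyl chains, gives 11.2 uM in this assay, so of the two numbers available the one for compound 1 is not separated from that of compound 2 beyond the scatter. Within the data shown here, compound 3 `CCCC1=C(OC)C(CCC)(CCC)C(=O)/C(=C(O)\C=C\c2ccc(Br)cc2)C1=O`, the bromo-substituted analogue, is recorded in this assay as "not determined" (no result reported), so it has no number here, and no step between measured compounds is available for comparison.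

Compound 4 `CCCCOC1=C(CCC)C(=O)/C(=C(O)/C=C/c2ccccc2)C(=O)C1(CCC)CCC` differs from compound 1 only in the alkoxy chain: propyl in place of isopropyl on a saturated chain carbon bound to an oxygen on an unsaturated carbon The two structures share the same atoms, joined differently, and nothing measured in the series speaks to this change. The step from compound 1 to compound 4 in this assay is therefore expected to be small, a 1.0-fold lower number from compound 1 to compound 4 (0.01 log units; within the scatter), and not beyond the scatter in either direction. For compound 4 the estimate in this assay is 13 uM, with a range from 5 uM to 35 uM.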

Compound 4, concentration for half-maximal effect: 8 uM
Estimate against measurement, compound 4: 1.6-fold (0.21 log units) above; the range from low to high includes it.
By their numbers in this assay, from the lowest: compounds 4, 2 and 1 (each within the scatter of the next).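

In this assay, within the data shown here, the change to propyl in place of isopropyl on a saturated chain carbon bound to an oxygen on an unsaturated carbon gives a 1.7-fold lower number from compound 1 to compound 4 (0.22 log units; within the scatter), the first step that isolates a single place. Within these two compounds, the branched isobutoxy and the straight butoxy chain are not separated at this position, so the branch makes no difference that can be read here. Nothing available explains the size of this step.

Open, from the compounds shown here alone, is whether a longer chain such as pentyloxy, or a chain ending in an amine or a carboxylic acid, would give a step beyond the scatter at this oxygen. The compounds shown also leave open how far this result carries to a core with prenyl chains in place of the propyl chains.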